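Compound 3 to compound 4: chlorine for fluorine

This account rests on a few compounds, and the source may have more. Where it says the series, first, only, none or still open, it means among the compounds named here.

Measured in an ADME assay on MT4 cells (Homo sapiens) for cytotoxicity, read by MTT assay; a lower number here means that less compound is tolerated, a higher number that more compound is tolerated:
compound 1 `O=C1c2ccccc2C(=O)N1CCOC(=S)N(C(=O)c1ccc(C(F)(F)F)cc1)c1ccc(Cl)cc1`: 10000 nM
compound 2 `O=C1c2ccccc2C(=O)N1CCOC(=S)N(C(=O)c1cc(F)ccc1F)c1ccc(Cl)cc1`: 54000 nM
compound 3 `O=C1c2ccccc2C(=O)N1CCOC(=S)N(C(=O)c1cc(F)cc(F)c1)c1ccc(Cl)cc1`: 59000 nM

Compound 3 shares the high end of this small set with compound 2. The gap there is only a 1.1-fold higher number from compound 2 to compound 3 (0.04 log units; within the scatter). Among the measured compounds shown here, the one clear gap involving compound 3 is a 5.9-fold higher number from compound 1 to compound 3 (0.77 log units; beyond the scatter).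

Compound 4 `O=C1c2ccccc2C(=O)N1CCOC(=S)N(C(=O)c1cc(Cl)cc(Cl)c1)c1ccc(Cl)cc1` has not yet been measured. It differs from compound 3 by 3,5-dichlorophenyl in place of 3,5-difluorophenyl on a carbonyl carbon, with 3,5-dichlorophenyl in place of 3,5-difluorophenyl on a carbonyl carbon. For the measured compounds named here, no measured step makes this exchange directly. The nearest guide is the modest 5.9-fold higher number from compound 1 to compound 3 (0.77 log units; beyond the scatter), read in reverse as a loss on leaving the difluorophenyl groups, so a modest fall in this assay is expected. The expected move is a 2.4-fold lower number from compound 3 to compound 4 (0.37 log units; beyond the scatter). For compound 4 the estimate is 25000 nM, with an expected range of 9000 nM to 60000 nM.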

Compound 4, half-maximal cytotoxic concentration: 32000 nM
Compound 4: the middle estimate sits 1.3-fold (0.11 log units) below what was measured; measured number inside the range.
By their numbers in this assay, from the lowest: compound 1; then compounds 4, 2 and 3 (each within the scatter of the next).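

In this assay, 3,5-dichlorophenyl in place of 3,5-difluorophenyl on the carbonyl carbon gives a 1.8-fold lower number from compound 3 to compound 4 (0.27 log units; within the scatter), and the comparison with the other difluorophenyl group gives a 1.7-fold lower number from compound 2 to compound 4 (0.23 log units; within the scatter), so chlorine and fluorine at this position cannot be told apart here. Compound 1 remains the only one set apart, with a 3.2-fold higher number from compound 1 to compound 4 (0.51 log units; beyond the scatter), which shows that its gap from the others does not depend on fluorine being on the ring. Nothing shown here accounts for these results. Going by these compounds, it remains open whether the low number of compound 1 follows from the trifluoromethyl group or from its place on the ring. On these data alone, a 4-chlorophenyl group would help to separate the two, and how an aminophenyl or carboxyphenyl group would behave on this carbonyl carbon is also open.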